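A few compounds are considered here, and "the series" means these few. Any claim that something is new, unique, unknown or untested is made for them only; others in the source may bear on it.

In a functional assay on MDA-MB-453 cells (Homo sapiens) for cytotoxicity, read by MTT assay, with a stated time of 48 h (on this read-out lower numbers stand for stronger inhibition and higher numbers for weaker inhibition), three compounds with the same core differ in one group on an aromatic carbon. Compound 1 `N#Cc1ccc(OCc2nnc(-c3ccccc3)o2)cc1F`, with hydrogen there, gives > 50000 nM, which is a limit of the assay and not a true number. Compound 2 `COc1ccc(-c2nnc(COc3ccc(C#N)c(F)c3)o2)cc1`, with methoxy at that place, gives 45500 nM. Compound 3 `N#Cc1ccc(OCc2nnc(-c3ccc(F)cc3)o2)cc1F`, with fluoro at that place, gives 25100 nM. The numbers for compound 2 and compound 3 lie within the usual scatter of each other, so compound 3 cannot be ranked apart from compound 2.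

Within the data shown here, compound 4 `N#Cc1ccc(OCc2nnc(-c3ccc(Cl)cc3)o2)cc1F` changes only that group, with chloro in place of fluoro on an aromatic carbon, para to a large group (chloro in place of fluoro on an aromatic carbon). Among the measured compounds shown here, three measured steps bear on this place. Fluoro in place of hydrogen gave an at least 1.9-fold lower number from compound 1 to compound 3 (0.29 log units; that floor lies within the scatter), methoxy in place of hydrogen gave an at least 1.0-fold lower number from compound 1 to compound 2 (0.04 log units; that floor lies within the scatter), and fluoro in place of methoxy gave a 1.8-fold lower number from compound 2 to compound 3 (0.26 log units; within the scatter). The first two are only floors, and none is shown to exceed the scatter.

Starting from compound 3 at 25100 nM, no shift beyond the scatter is expected in this assay, in either direction. The expected step is a 1.1-fold lower number from compound 3 to compound 4 (0.06 log units; within the scatter). The estimate for compound 4 is 22000 nM, with an expected range of 9000 nM to 50000 nM.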

Compound 4, half-maximal inhibitory concentration: > 50000 nM
Compound 4 ended at the assay's limit; the forecaster's own chance of this, stated with the estimate: 15%; middle value at least 2.2-fold (0.35 log units) from the limit.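

Chloro in place of fluoro is the only swap shown of one halogen for another on this aromatic carbon, and in this assay it gives an at least 1.9-fold higher number from compound 3 to compound 4 (0.29 log units; that floor lies within the scatter). Chloro in place of methoxy gives an at least 1.0-fold higher number from compound 2 to compound 4 (0.04 log units; that floor lies within the scatter), while the step between compound 1 and compound 4 cannot be read because both compounds stand at a limit of the assay: the limit of > 50000 nM in this assay, at which 2 of the 4 values shown sit. What the earlier compounds did not show is that a halogen at this place need not come with a measured number: chloro gives no lower reading than fluoro, although both floors lie within the scatter, so compound 4 cannot yet be firmly ranked apart from compound 3 or compound 2.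

Going by these compounds, the size of the change from 4-fluorophenyl to 4-chlorophenyl stays open, since a limit does not tell how far the true number of compound 4 lies past it. Also open, on these data alone, is how bromo, an amine or a carboxylic acid on this aromatic carbon would read in this assay, and whether any group here can move the number beyond the scatter.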